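A few compounds are considered here, and "the series" means these few. Any claim that something is new, unique, unknown or untested is made for them only; others in the source may bear on it.

Of the compounds shown here, three sharing one core have been measured in a functional assay on A549 cells (Homo sapiens) for antiproliferative activity, read by MTT assay, with a stated time of 72 h; on this read-out higher numbers stand for weaker inhibition and lower numbers for stronger inhibition: compound 1 `COc1cc(-n2cnc3ccc(-c4cccc(Cl)c4)cc32)cc(OC)c1OC` gives 7050 nM, compound 2 `COc1cc(-n2cnc3ccc(-c4cccc(C)c4)cc32)cc(OC)c1OC` gives 3820 nM, and compound 3 `COc1cc(-n2cnc3ccc(-c4ccc(C)cc4)cc32)cc(OC)c1OC` gives 1940 nM. Compound 3 stands level with compound 2 within the scatter, and the gap to the chlorinated compound is a 3.6-fold lower number from compound 1 to compound 3 (0.56 log units; beyond the scatter). Compound 4 `COc1cccc(-c2ccc3ncn(-c4cc(OC)c(OC)c(OC)c4)c3c2)c1` differs from compound 3 in one place: 3-methoxyphenyl in place of 4-methylphenyl on an aromatic carbon, with 3-methoxyphenyl in place of 4-methylphenyl on an aromatic carbon. The nearest evidence is the step putting 4-methylphenyl in place of 3-methylphenyl, a 2.0-fold lower number from compound 2 to compound 3 (0.29 log units; within the scatter), which this change partly reverses. Among the compounds with values here, no measured compound carries methoxy on that ring, so only a small rise, probably within the scatter, is expected in this assay. The expected step is a 1.5-fold higher number from compound 3 to compound 4 (0.19 log units; within the scatter). For compound 4 the estimated value is 3000 nM, with an expected range of 1200 nM to 7500 nM.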

Compound 4, half-maximal inhibitory concentration: 3180 nM
Compound 4: middle estimate off by 1.1-fold (0.03 log units), on the low side; the measured number falls inside the stated range.
By their numbers in this assay, from the lowest: compounds 3, 4, 2 and 1 (each within the scatter of the next, the first and the last beyond it).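

In this assay, within the data shown here, the first oxygen-bearing group at this position, 3-methoxyphenyl in place of 4-methylphenyl, stays within the scatter, a 1.6-fold higher number from compound 3 to compound 4 (0.21 log units; within the scatter), and so does methoxy in place of methyl, a 1.2-fold lower number from compound 2 to compound 4 (0.08 log units; within the scatter). Only methoxy in place of chloro goes beyond the scatter, a modest step of a 2.2-fold lower number from compound 1 to compound 4 (0.35 log units; beyond the scatter), so compound 4 sits with compound 2 and compound 3 rather than adding a clear gain. Still open, on these data alone, is how an amine or a carboxylic acid on this ring would behave, and whether 4-methoxyphenyl would match 4-methylphenyl. Nothing measured here offers an explanation for these steps.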